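This account rests on a few compounds, and the source may have more. Where it says the series, first, only, none or still open, it means among the compounds named here.

Compound 1, `Cc1cc(-c2nc(C(F)(F)F)n(CC[C@@H](O)C[C@@H](O)CC(=O)O)c2-c2ccc(F)cc2)cc(C)c1F`: 32 nM
Compound 2, `CC(C)c1nc(-c2ccc(F)cc2)c(-c2ccc(F)cc2)n1CC[C@@H](O)C[C@@H](O)CC(=O)O`: 316 nM
Compound 3, `O=C(O)C[C@H](O)C[C@H](O)CCn1c(C(F)(F)F)nc(-c2ccc(F)cc2)c1-c1ccccc1`: 201 nM

All three were tested in an assay on microsomes from liver for inhibition of 3-hydroxy-3-methylglutaryl-coenzyme A reductase (Rattus norvegicus); on this read-out higher numbers stand for weaker inhibition and lower numbers for stronger inhibition. Compound 3 holds the second highest of the three numbers. Its nearest neighbour is compound 2, whose value falls within the usual scatter around that of compound 3, so no difference between the two can be read. Compound 1 stands furthest away, with a lower number that lies beyond the scatter. Compound 4, `O=C(O)C[C@H](O)C[C@H](O)CCn1c(C(F)(F)F)nc(-c2ccc(F)cc2)c1-c1cccnc1`, has not yet been measured in this assay. It differs from compound 3 in one place: pyridin-3-yl in place of phenyl on an aromatic carbon. Within the data shown here, no pair of measured compounds shows what this change does, so the expectation rests on compound 3 alone, and only a small step, within the scatter, is expected. Compound 4 is therefore expected to give 250 nM, within a range from 80 nM to 800 nM. The expected step of a 1.2-fold higher number from compound 3 to compound 4 (0.09 log units; within the scatter) is estimated to stay within the scatter.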

Compound 4, half-maximal inhibitory concentration: > 1000 nM
Compound 4 gave a limit, no number (the forecaster's own chance of this, stated with the estimate: 5%); middle value at least 4.0-fold (0.60 log units) away from the limit.
By their numbers in this assay, from the lowest: compound 1; then compounds 3 and 2 (each within the scatter of the next). At a limit, above all of these: compound 4.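

In this assay, among these compounds, putting pyridin-3-yl in place of phenyl on this aromatic carbon gives an at least 4.9-fold higher number from compound 3 to compound 4 (0.69 log units; beyond the scatter), the first change at a single place that can be read in this set. Swapping one ring carbon of this group for nitrogen is thus enough to weaken inhibition beyond the scatter. Compound 4 gives a limit, not a number: the limit of > 1000 nM in this assay, at which 1 of the 4 values shown sits.

Going by these compounds, how far the weakening goes therefore stays open. Also open, on these data alone, is whether pyridin-4-yl, or a phenyl carrying an amine or a methoxy group, would behave the same way at this position.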